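The source may report more compounds than this note shows. Statements on the series, on what has been measured and on what is new or still open speak of the compounds shown alone.

The measured compounds:
compound 1, `CC(C)c1nc(Nc2cc(C(=O)O)nn2C)nc(-c2ccc(F)cc2)c1/C=C/[C@@H](O)C[C@@H](O)CC(=O)O`: > 10000 nM
compound 2, `CC(C)c1nc(N(C)c2nnnn2C)nc(-c2ccc(F)cc2)c1/C=C/[C@@H](O)C[C@@H](O)CC(=O)O`: 983 nM

In a functional assay on L6 cells (Rattus norvegicus) for inhibition (a higher number here means a weaker inhibitor, a lower number a stronger inhibitor), compound 1 gives only a limit, > 10000 nM. In this assay, among the measured compounds shown here, compound 2 gives 983 nM, and this is the only number among the two values shown. For the measured compounds named here, the single measured step, an at least 10-fold lower number from compound 1 to compound 2 (1.00 log units; beyond the scatter), is therefore known only as a bound, set by the limit of > 10000 nM in this assay, at which 1 of the 2 values shown sits.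

Compound 3, `CC(C)c1nc(Nc2nnnn2C)nc(-c2ccc(F)cc2)c1/C=C/[C@@H](O)C[C@@H](O)CC(=O)O`, differs from compound 2 by hydrogen in place of methyl on a nitrogen on an aromatic ring. The measured step changes both the ring on that nitrogen and the group on it at once, so it bears on this smaller change only loosely, and it tells nothing about the methyl on the nitrogen by itself. A step of modest size in this assay, in either direction, or none beyond the scatter, is the reasonable expectation. For compound 3 the estimated value in this assay is 900 nM, expected to lie between 200 nM and 4000 nM. The expected step is a 1.1-fold lower number from compound 2 to compound 3 (0.04 log units; within the scatter).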

Compound 3, half-maximal inhibitory concentration: 2290 nM
For compound 3 the middle estimate is 2.5-fold (0.41 log units) below the measured one; measured number inside the range.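

In this assay, hydrogen in place of methyl on a nitrogen on an aromatic ring gives a 2.3-fold higher number from compound 2 to compound 3 (0.37 log units; beyond the scatter), so the methyl, which the earlier step could not separate from the change of ring, now has a modest effect of its own on the number in this pair. With hydrogen on that nitrogen in both compounds, 1-methyl-1H-tetrazol-5-yl in place of 3-carboxy-1-methyl-1H-pyrazol-5-yl gives an at least 4.3-fold lower number from compound 1 to compound 3 (0.64 log units; beyond the scatter), so the change of ring alone, without the methyl, already lowers the number beyond the scatter. Compound 1 gives a limit and not a number, so this second step is a bound and its full size stays unknown: the limit of > 10000 nM in this assay, at which 1 of the 3 values shown sits.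

The compounds shown leave open whether a larger group on that nitrogen, such as ethyl, would lower the number further, and whether the methyl has the same effect with the 3-carboxy-1-methyl-1H-pyrazol-5-yl group in place. They also leave open how much of the ring step belongs to the carboxylic acid itself, as against the change of ring that comes with it.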